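A few compounds are considered here, and "the series" means these few. Any claim that something is new, unique, unknown or untested is made for them only; others in the source may bear on it.

Compound 1 `COc1cc(C(O)(C(F)(F)F)C(F)(F)F)cnc1N1CCN(S(=O)(=O)c2ccc(N)nc2)CC1`: in an ADME assay (liver) for metabolic stability, with Liver microsome (Rattus norvegicus) as the target, using microsomes and NADPH, with a stated time of 30 min, tested at 1 uM (on this read-out higher numbers stand for fast clearance and lower numbers for slow clearance), compound 1 gives < 14 mL.min-1.g-1, which is a limit of the assay and not a number (the limit of < 14 mL.min-1.g-1 in this assay, at which 1 of the 3 values shown sits).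
Compound 2 `Cc1csc(-c2cc(C(O)(C(F)(F)F)C(F)(F)F)cnc2N2CCN(S(=O)(=O)c3ccc(N)nc3)CC2)c1`: compound 2 gives 399 mL.min-1.g-1.
Compound 3 `Nc1ccc(S(=O)(=O)N2CCN(c3ncc(C(O)(C(F)(F)F)C(F)(F)F)cc3-c3ccccc3O)CC2)cn1`: compound 3 gives 125 mL.min-1.g-1.

Among the two numbers, compound 3 stands lowest, with compound 2 nearest; the step is a 3.2-fold lower number from compound 2 to compound 3 (0.50 log units; beyond the scatter). Compound 4 `COc1cncc(-c2cc(C(O)(C(F)(F)F)C(F)(F)F)cnc2N2CCN(S(=O)(=O)c3ccc(N)nc3)CC2)c1` differs from compound 3 by 5-methoxypyridin-3-yl in place of 2-hydroxyphenyl on an aromatic carbon. Among the measured compounds shown here, two steps bear on this change: an at least 28-fold higher number from compound 1 to compound 2 (1.45 log units; beyond the scatter) and an at least 8.9-fold higher number from compound 1 to compound 3 (0.95 log units; beyond the scatter) show that an aromatic ring on this carbon gives a far higher number than methoxy, while a 3.2-fold lower number from compound 2 to compound 3 (0.50 log units; beyond the scatter) shows that swapping one aromatic ring for another moves the number only modestly. Compound 4 keeps an aromatic ring there, so a step of a 1.1-fold lower number from compound 3 to compound 4 (0.06 log units; within the scatter) is expected, modest at most. Compound 4 is therefore estimated at 110 mL.min-1.g-1, between 35 mL.min-1.g-1 and 330 mL.min-1.g-1.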

Compound 4, intrinsic clearance in microsomes: 58 mL.min-1.g-1
Estimate against measurement, compound 4: 1.9-fold (0.28 log units) above, within the range that was stated.
By their numbers in this assay, from the lowest: compound 4; then compound 3; then compound 2. At a limit, below all of these: compound 1.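

Swapping one aromatic ring for another at this carbon, ortho to a large group, can move the number further than the earlier compounds showed: in this assay the change gives a 2.2-fold lower number from compound 3 to compound 4 (0.33 log units; beyond the scatter) and a 6.9-fold lower number from compound 2 to compound 4 (0.84 log units; beyond the scatter). Even so, the ring with one hetero atom does not return to the methoxy level, with an at least 4.1-fold higher number from compound 1 to compound 4 (0.61 log units; beyond the scatter). That comparison rests on compound 1, whose value is a limit of the assay and not a number: the limit of < 14 mL.min-1.g-1 in this assay, at which 1 of the 4 values shown sits. From the compounds shown here alone, whether an amine or a carboxylic acid on this carbon would come closer to compound 1 stays open.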